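This account rests on a few compounds, and the source may have more. Where it says the series, first, only, none or still open, it means among the compounds named here.

Measured compounds:
- compound 1 `COc1ccc([C@@H]2C/C(=N/OCc3cn(-c4ccc(C(=O)c5ccccc5)cc4)nn3)c3cc(CC=C(C)C)c(OC)cc3O2)cc1`: 34%
- compound 2 `COc1cc2c(cc1CC=C(C)C)C(=O)C[C@@H](c1ccc(Oc3ccc(F)cc3)cc1)O2`: 27%
- compound 3 `CCOc1ccc([C@@H]2CC(=O)c3cc(CC=C(C)C)c(OC)cc3O2)cc1`: 37%

In a functional assay on A549 cells (Homo sapiens) for inhibition, read by sulforhodamine B assay, with a stated time of 48 h, tested at 50 uM (on this read-out higher numbers stand for more inhibition of growth at the one concentration tested and lower numbers for less inhibition of growth), compound 1 gives 34%. That number lies within the scatter of both compound 2 and compound 3, so no order can be claimed among the three.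

The next compound, compound 4 `COc1ccc([C@@H]2C/C(=N/OCc3cn(-c4ccc(NC(=O)c5ccccc5)cc4)nn3)c3cc(CC=C(C)C)c(OC)cc3O2)cc1`, keeps the core of compound 1 and changes one group: benzamido in place of benzoyl on an aromatic carbon. In words, benzamido stands in place of benzoyl on an aromatic carbon, and this brings in one hydrogen-bond donor.

Within the data shown here, only one measured step is available, a number 10 percentage points higher from compound 2 to compound 3 (within the scatter). It lies within the scatter, and it swaps a different group, ethyl in place of 4-fluorophenyl on an oxygen, so it bears on this change only weakly. Among the measured compounds shown here, no measured pair tests benzoyl against benzamido. With so little evidence, no shift beyond the scatter is expected in this assay, and no direction can be favoured.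

The expected change is small, an estimated a number 1 percentage points higher from compound 1 to compound 4 (within the scatter). For compound 4 the estimate is 35%, with an expected range of 20% to 50%.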

Compound 4, percent growth inhibition at one concentration: 31%
Estimate against measurement, compound 4: 4 percentage points above, and the stated range covers the measured number.
By their numbers in this assay, from the lowest: compounds 2, 4, 1 and 3 (each within the scatter of the next).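

Benzamido in place of benzoyl, on an aromatic carbon para to a large group, gives a number 3 percentage points lower from compound 1 to compound 4 (within the scatter) in this assay and is the first direct test of a change at this place on the molecule. Among these compounds, the earlier compounds could not show this, as their only measured step swapped a different group on an oxygen. Here, the hydrogen-bond donor that benzamido brings in and its added nitrogen leave no shift that can be told apart from the scatter, and nothing available explains this result.

The compounds shown leave open whether an amine or a carboxylic acid on this aromatic carbon would move the number beyond the scatter. They also leave open whether benzoyl and benzamido would still read alike at other concentrations or on other cells.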